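The source may report more compounds than this note shows. Statements on the series, on what has been measured and on what is new or still open speak of the compounds shown alone.

Three compounds have been measured in an assay on microsomes from liver for inhibition of 3-hydroxy-3-methylglutaryl-coenzyme A reductase (Rattus norvegicus); a higher number here means a weaker inhibitor, a lower number a stronger inhibitor:

compound 1, `CC(C)c1c(C(=O)N(C)Cc2ccccc2)nn(-c2ccc(F)cc2)c1OC[C@@H](O)C[C@@H](O)CC(=O)O`, 5.2 nM
compound 2, `CC(C)c1c(C(=O)N2CCCCC2)nn(-c2ccc(F)cc2)c1OC[C@@H](O)C[C@@H](O)CC(=O)O`, 47 nM
compound 3, `COc1ccccc1CNC(=O)c1nn(-c2ccc(F)cc2)c(OC[C@@H](O)C[C@@H](O)CC(=O)O)c1C(C)C`, 22 nM

All three share one core and differ only in the group attached to the amide carbonyl carbon. Compound 3 holds the second highest number of the three: the step of a 4.2-fold higher number from compound 1 to compound 3 (0.63 log units; beyond the scatter) places it above compound 1, and the step of a 2.1-fold lower number from compound 2 to compound 3 (0.33 log units; beyond the scatter) places it below compound 2.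

Compound 4, `CC(C)c1c(C(=O)NCc2ccc(Cl)cc2)nn(-c2ccc(F)cc2)c1OC[C@@H](O)C[C@@H](O)CC(=O)O`, keeps the benzylamino arrangement of compound 3 and changes only the substituent on the phenyl ring: 4-chlorophenyl in place of 2-methoxyphenyl on a saturated chain carbon bound to an amide-type nitrogen. Among the compounds with values here, no measured pair probes such a change on the benzyl ring itself. The steps that do exist all exchange the whole group on the carbonyl carbon, and they were modest: a 9.0-fold higher number from compound 1 to compound 2 (0.96 log units; beyond the scatter), a 4.2-fold higher number from compound 1 to compound 3 (0.63 log units; beyond the scatter) and a 2.1-fold lower number from compound 2 to compound 3 (0.33 log units; beyond the scatter). The change from compound 3 to compound 4 is smaller in scope than those; the expected shift in this assay is accordingly smaller still, and may not exceed the scatter; its direction cannot be read from the three compounds. The expected step is therefore a 1.5-fold lower number from compound 3 to compound 4 (0.17 log units; within the scatter). Compound 4 is estimated at 15 nM, within a range from 5 nM to 50 nM.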

Compound 4, half-maximal inhibitory concentration: 6.7 nM
Beside the measured number, compound 4's estimate is 2.2-fold (0.35 log units) above it; measured number inside the range.
By their numbers in this assay, from the lowest: compounds 1 and 4 (each within the scatter of the next); then compound 3; then compound 2.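

Compound 4 shows that, in this assay, the substituted phenyl ring on the saturated chain carbon bound to an amide-type nitrogen affects the result even when the rest of the group stays the same: 4-chlorophenyl in place of 2-methoxyphenyl gives a 3.3-fold lower number from compound 3 to compound 4 (0.52 log units; beyond the scatter) and goes beyond the scatter, whereas every earlier step exchanged the whole group on the carbonyl carbon. The (4-chlorobenzyl)amino group also gives a 7.0-fold lower number from compound 2 to compound 4 (0.85 log units; beyond the scatter) against the piperidin-1-yl group, while a 1.3-fold higher number from compound 1 to compound 4 (0.11 log units; within the scatter) means that it cannot be told apart from the benzyl(methyl)amino group of compound 1 in this assay. Nothing available bears on what lies behind the shift from compound 3 to compound 4.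

That step changes both the substituent and its ring position at once, so the compounds shown cannot separate the effect of chlorine versus methoxy from the effect of where the group sits. A 2-chlorobenzyl or a 4-methoxybenzyl group on the same nitrogen would divide those two changes, and an unsubstituted benzyl group with the amide hydrogen kept would show what either substituent adds.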